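Swapping the ring on a carbamate in a cytotoxicity assay

The compounds below may be only part of what the source reports. "The series", "measured", "known", "first", "only" and "open" are said of these compounds alone.

Compound 3 `CCCCC1CCC(OC(=O)N[C@@H](CC(C)C)C(=O)N[C@@H](C[C@@H]2CCNC2=O)C(O)S(=O)(=O)O)CC1` has been tested in a toxicity assay on Huh-7 cells (Homo sapiens) for cytotoxicity; a lower number here means that less compound is tolerated, a higher number that more compound is tolerated. There compound 3 gives 59100 nM, the lowest of the two numbers recorded, and its nearest neighbour is compound 1 `CCCCC1CCC(OC(=O)N[C@@H](CC(C)C)C(=O)N[C@H](C=O)C[C@@H]2CCNC2=O)CC1`, which gives 63300 nM, so that the step of a 1.1-fold lower number from compound 1 to compound 3 (0.03 log units; within the scatter) separates them. Compound 2 `CC(C)C[C@H](NC(=O)OC1CCC(F)(F)CC1)C(=O)N[C@H](C=O)C[C@@H]1CCNC1=O` reaches only a limit of this assay, reported as > 100000 nM. That is the limit of > 100000 nM in this assay, at which 1 of the 3 values shown sits.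

Compound 4 `CC(C)C[C@H](NC(=O)OC1CCC(F)(F)CC1)C(=O)N[C@@H](C[C@@H]1CCNC1=O)C(O)S(=O)(=O)O` has not been measured. It differs from compound 3 in one place: a group of 8 heavy atoms (6 carbon, 2 fluorine; one six-membered non-aromatic ring of carbon only) in place of a group of 10 heavy atoms (10 carbon; one six-membered non-aromatic ring of carbon only), on an oxygen next to a carbonyl group. The same exchange has been made once already, between compound 1 and compound 2, where it produced an at least 1.5-fold higher number from compound 1 to compound 2 (0.19 log units; that floor lies within the scatter), a move toward more compound being tolerated that ran into the top of the assay. Since compound 1 and compound 3 sit so close together in this assay, that earlier step is the best guide available, and a similar or larger move upward is expected here, with a real chance that only a limit is reported again.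

The step expected for compound 4 is therefore a 2.0-fold higher number from compound 3 to compound 4 (0.31 log units; beyond the scatter). Compound 4 is estimated to give 120000 nM in this assay, within a range from 60000 nM to 300000 nM.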

Compound 4, half-maximal cytotoxic concentration: > 100000 nM
Compound 4 gave a limit, no number (the forecaster's own chance of this, stated with the estimate: 60%); the middle value does not contradict the limit.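

In this assay, 4,4-difluorocyclohexyl in place of the group of 10 heavy atoms, on an oxygen next to a carbonyl group, gives an at least 1.6-fold higher number from compound 3 to compound 4 (0.22 log units; that floor lies within the scatter), so this step alone does not establish a real difference. What is new is that the same outcome appears on a second core, the one carrying hydroxy(sulfo)methyl rather than formyl: the same change on two cores in this assay, an at least 1.5-fold higher number (0.19 log units; that floor lies within the scatter) from compound 1 to compound 2 and an at least 1.6-fold higher number (0.22 log units; that floor lies within the scatter) from compound 3 to compound 4; the limit leaves it open whether they differ. Both compounds with 4,4-difluorocyclohexyl, compound 2 and compound 4, end in a limit and not a number: the limit of > 100000 nM in this assay, at which 2 of the 4 values shown sit.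

Going by these compounds, the step from compound 2 to compound 4 cannot be read, which leaves open whether hydroxy(sulfo)methyl in place of formyl makes any difference once 4,4-difluorocyclohexyl is present, and the true size of the ring exchange on either core also remains unknown. The compounds shown also say nothing about how a plain cyclohexyl ring, a cyclohexyl ring with a single fluorine or one carrying an amine would behave at this oxygen, and such groups could show whether the butyl chain or the fluorines account for the gap.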